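Phenyl for methyl on the lactone ring of compound 1

This account rests on a few compounds, and the source may have more. Where it says the series, first, only, none or still open, it means among the compounds named here.

Compound 1, with structure `C=C1C(=O)O[C@H](c2ccc3ccccc3c2)[C@H]1C`, is the weaker of the two measured compounds in a functional assay on BXPC-3 cells (Homo sapiens) for cytotoxicity, read by MTT assay, with a stated time of 72 h, tested at 1 uM; a lower number here means a stronger effect, a higher number a weaker effect of the compound at the concentration tested: compound 1 gives 104%, while compound 2, with structure `C=C1C(=O)O[C@@H](c2ccccc2)[C@H]1c1ccccc1`, gives 51% in this assay, a gap beyond the usual scatter. The two compounds differ in more than one place, so their values are only compared, not traced to one change.

Compound 3, with structure `C=C1C(=O)O[C@H](c2ccc3ccccc3c2)[C@H]1c1ccccc1`, differs from compound 1 by a single change: phenyl in place of methyl on a saturated ring carbon. Among the measured compounds shown here, no measured pair shows this change alone, so its effect has no direct precedent. Since compound 2, which carries a phenyl on the corresponding saturated ring carbon, gives 51%, a move toward a lower percentage is expected for compound 3 in this assay. The estimated step of a number 42 percentage points lower from compound 1 to compound 3 (beyond the scatter) is expected to be beyond the scatter. Compound 3 is therefore expected to give about 62%, within a range from 35% to 95%.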

Compound 3, a percentage reported as activity, at one concentration (the size of the read-out at that concentration, not a potency): 60%
Estimate against measurement, compound 3: 2 percentage points above, and the stated range covers the measured number.
By their numbers in this assay, from the lowest: compounds 2 and 3 (each within the scatter of the next); then compound 1.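

In this assay, among the compounds shown here, the step of a number 44 percentage points lower from compound 1 to compound 3 (beyond the scatter) is the first reading of phenyl in place of methyl on a saturated ring carbon with nothing else altered, since the earlier pair differed in more than one place. It shows that this position, two ring bonds from the ring oxygen, is not indifferent to what it carries: this one change alone makes a large difference to the read-out on the core of compound 1. No measurement at hand says why the number moves.

The compounds shown leave open how other groups would behave at this carbon, such as an ethyl chain, a benzyl group or an amine. They also leave open whether the same change gives a step of this size on another core.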